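Swapping the Benzyl Substituent on an Adenosine A3 Ligand

A few compounds are considered here, and "the series" means these few. Any claim that something is new, unique, unknown or untested is made for them only; others in the source may bear on it.

Measured so far:
Compound 1, `CCC(CC)Nc1nc(Cl)nc2c1ncn2[C@H]1[C@H](O)[C@H](O)[C@@H]2C[C@@H]21`: 52 nM
Compound 2, `O[C@@H]1[C@H](O)[C@@H]2C[C@@H]2[C@H]1n1cnc2c(NCc3ccccc3OCCF)nc(Cl)nc21`: 10.3 nM

In an assay on CHO cells for displacement of a labelled ligand from adenosine receptor A3 (Homo sapiens), with a stated time of 60 min (on this read-out higher numbers stand for weaker inhibition and lower numbers for stronger inhibition), compound 2 gives 10.3 nM, the lowest of the two numbers shown; compound 1 gives 52 nM, a higher number, and that gap lies beyond the scatter. Compound 3, `O[C@@H]1[C@H](O)[C@@H]2C[C@@H]2[C@H]1n1cnc2c(NCc3cc(F)ccc3F)nc(Cl)nc21`, keeps the shared core of compound 2 and changes only the aromatic group: 2,5-difluorophenyl in place of 2-(2-fluoroethoxy)phenyl on a saturated chain carbon bound to a nitrogen on an aromatic ring. Among the compounds with values here, no measured pair shows what this exchange does, so for compound 3 a step from a 1.1-fold lower number from compound 2 to compound 3 (0.06 log units; within the scatter) is expected, close to none beyond the scatter. Compound 3 is therefore estimated at 9 nM in this assay, with a range from 2.5 nM to 35 nM.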

Compound 3, inhibition constant: 16.5 nM
For compound 3 the middle estimate is 1.8-fold (0.26 log units) below the measured one, within the range that was stated.
By their numbers in this assay, from the lowest: compounds 2 and 3 (each within the scatter of the next); then compound 1.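

In this assay, the exchange gives a 1.6-fold higher number from compound 2 to compound 3 (0.20 log units; within the scatter), so at this position the two aromatic groups cannot be told apart, even though 2,5-difluorophenyl has no hydrogen-bond acceptor and 2-(2-fluoroethoxy)phenyl has one. On the nitrogen on the aromatic ring, 2,5-difluorobenzyl in place of pentan-3-yl gives a 3.2-fold lower number from compound 1 to compound 3 (0.50 log units; beyond the scatter), a modest gain that a substituted benzyl group can deliver without any ether chain. Nothing available explains either step. As far as these compounds go, whether a phenyl ring carrying an amine or a carboxylic acid would keep numbers in this range remains open.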